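The source may hold more compounds than are shown below. What is called first, only, known or untested is meant among the compounds shown, and "the series" means these compounds.

Compound 1 `CC(=O)Nc1cccc(Cn2cc(-c3ccc4cn[nH]c4c3)ccc2=O)c1`: in an assay for inhibition of MAP kinase-interacting serine/threonine-protein kinase 2 (Homo sapiens), read by luminescence and ADP-Glo, with a stated time of 2 h (on this read-out higher numbers stand for weaker inhibition and lower numbers for stronger inhibition), compound 1 gives 43 nM.
Compound 2 `O=c1ccc(-c2ccc3cn[nH]c3c2)cn1Cc1cccc(C(F)(F)F)c1`: in this assay compound 2 gives 32 nM.

Among the measured compounds shown here, compound 2 has the lowest of the two numbers so far, but its nearest neighbour is compound 1, and the step of a 1.3-fold lower number from compound 1 to compound 2 (0.13 log units; within the scatter) is within the usual scatter, so the two cannot be ranked against each other. The next compound, compound 3 `O=c1ccc(-c2ccc3cn[nH]c3c2)cn1Cc1cccc(Cl)c1`, keeps the shared core and the benzyl group of compound 2 and changes only the substituent on that benzyl ring: chloro in place of trifluoromethyl on an aromatic carbon, on an aromatic carbon of a six-membered aromatic ring of carbon only, meta to a large group.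

For the measured compounds named here, only one measured step exists, and it concerns a different exchange at the same place: a 1.3-fold lower number from compound 1 to compound 2 (0.13 log units; within the scatter), which was within the scatter. Going by the values given here, no measured step swaps trifluoromethyl for chloro, so nothing directly bears on this change. Given that the one swap seen at this position, a 1.3-fold lower number from compound 1 to compound 2 (0.13 log units; within the scatter), barely moved the number, the expectation for compound 3 is a step of a 1.1-fold higher number from compound 2 to compound 3 (0.04 log units; within the scatter), that is, nothing beyond the scatter. Compound 3 is therefore estimated at 35 nM, with a range from 14 nM to 90 nM.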

Compound 3, half-maximal inhibitory concentration: 40 nM
The estimate for compound 3 lay 1.1-fold (0.06 log units) below the measured number, within the range that was stated.
By their numbers in this assay, from the lowest: compounds 2, 3 and 1 (each within the scatter of the next).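

Replacing trifluoromethyl, with 4 heavy atoms, by chloro, with 1 heavy atom, gives a 1.3-fold higher number from compound 2 to compound 3 (0.10 log units; within the scatter) in this assay, so this much smaller group cannot be told apart from the larger one at this place on the ring. The comparison with the acetamido group gives the same kind of result, a 1.1-fold lower number from compound 1 to compound 3 (0.03 log units; within the scatter), which means that all three pairs among these compounds now lie within the scatter, and none of the three compounds goes against this flat picture. The compounds therefore show that these three quite different substituents all read alike at this one position, but nothing available explains why the number stays so level here.

Going by these compounds, it remains open whether any group at this place would move the number beyond the scatter, for example an amine, a carboxylic acid or a longer chain, or simply a hydrogen in place of a substituent. It is also unknown whether chloro or trifluoromethyl would read the same on another carbon of this ring, since all three compounds carry their group at the same position.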